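Hydrogen for Methyl on Compound 1

The compounds below may be only part of what the source reports. "The series", "measured", "known", "first", "only" and "open" are said of these compounds alone.

Going by the values given here, in a functional assay on A549 cells (Homo sapiens) for antiproliferative activity, with a stated time of 5 days (on this read-out higher numbers stand for weaker inhibition and lower numbers for stronger inhibition), compound 1 `CC1OC2(C=CC(=O)C=C2)N(c2nc(-c3ccc4ccccc4c3)nn2-c2ccc3ccccc3c2)C1=O` gives 300 nM as the lower of the two numbers so far. Compound 2 `COc1ccc(-n2nc(-c3ccc4ccccc4c3)nc2N2C(=O)C(C)OC23C=CC(=O)C=C3)cc1` gives 860 nM and so inhibits less strongly. Compound 3 `O=C1C=CC2(C=C1)OCC(=O)N2c1nc(-c2ccc3ccccc3c2)nn1-c1ccc2ccccc2c1` is still unmeasured. Compared with compound 1 it carries hydrogen in place of methyl on a saturated ring carbon and nothing else. Among the compounds with values here, the one measured step of a 2.9-fold higher number from compound 1 to compound 2 (0.46 log units; beyond the scatter) is modest but sits at another place, so it gives no direct guide. Within the data shown here, with no measured step at this place, a change within the scatter is expected in this assay and either direction stays open. The estimated step is a 1.2-fold higher number from compound 1 to compound 3 (0.07 log units; within the scatter) and nothing firmer. For compound 3 the estimate is 350 nM with an expected range from 120 nM to 1000 nM for now.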

Compound 3, half-maximal inhibitory concentration: 250 nM
Compound 3: the middle estimate sits 1.4-fold (0.15 log units) above what was measured; measured number inside the range.
By their numbers in this assay, from the lowest: compounds 3 and 1 (each within the scatter of the next); then compound 2.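

Hydrogen in place of methyl on the saturated ring carbon next to the ring oxygen gives a 1.2-fold lower number from compound 1 to compound 3 (0.08 log units; within the scatter) in this assay and so the activity of compound 1 does not depend on this methyl. This position therefore accepts the loss of its only carbon substituent without a change beyond the scatter. No measurement shown here offers an explanation for this result.

The compounds shown leave open what a longer chain such as propyl, or an amine or a carboxylic acid, would do at this carbon.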